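The source may report more compounds than this note shows. Statements on the series, on what has been measured and on what is new or still open speak of the compounds shown alone.

The series shares one core, seen in compound 1 `CNC(=O)CC1CCc2cc(OC)c(OC)cc21`, compound 2 `COc1cc2c(cc1OC)C(CC(=O)NC(C)C)CC2` and compound 3 `COc1cc2c(cc1OC)C(CC(=O)NC(C)(C)C)CC2`, and these three differ only in the group on the amide nitrogen. In a functional assay on the whole organism (strain Wistar) for inhibition, with Rattus norvegicus as the target, read by paw edema, with stated times of 60 min and 24 h, at a dose of 100 mg/kg by the oral route (on this read-out higher numbers stand for more inhibition at the one dose given (going by the name of the read-out) and lower numbers for less inhibition), compound 1 gives 33.3%, compound 2 gives 30% and compound 3 gives 40%. On the bare numbers compound 2 stands lowest of the three, nearest to compound 1 and furthest from compound 3, but every gap lies within the scatter: a number 3.3 percentage points lower from compound 1 to compound 2 (within the scatter), a number 6.7 percentage points higher from compound 1 to compound 3 (within the scatter) and a number 10 percentage points higher from compound 2 to compound 3 (within the scatter).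

Compound 4 `COc1cc2c(cc1OC)C(CC(=O)N1CCNCC1)CC2` has not yet been measured. It differs from compound 2 by piperazin-1-yl in place of isopropylamino on a carbonyl carbon. The three measured steps bear on this change, since each of them also alters what is attached to the amide nitrogen, and none of them moved the read-out beyond the scatter. Accordingly the step expected in this assay is a number 2 percentage points higher from compound 2 to compound 4 (within the scatter), which is none beyond the scatter, with the direction left open. Compound 4 is therefore estimated to give 32% in this assay, with a range from 15% to 50%.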

Compound 4, a percentage reported as inhibition, in the whole organism at one dose (the size of the read-out at that dose, not a potency): 65%
Compound 4: middle estimate off by 33 percentage points, on the low side, outside the stated range (above it).
By their numbers in this assay, from the lowest: compounds 2, 1 and 3 (each within the scatter of the next); then compound 4.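

Piperazin-1-yl on the carbonyl carbon is the first change at this position to move the read-out beyond the scatter in this assay, with a number 35 percentage points higher from compound 2 to compound 4 (beyond the scatter), a number 31.7 percentage points higher from compound 1 to compound 4 (beyond the scatter) and a number 25 percentage points higher from compound 3 to compound 4 (beyond the scatter). The position therefore responds to what is placed there, which methylamino, isopropylamino and (tert-butyl)amino did not show, as those three open-chain groups stayed within the scatter of one another and compound 4 stands apart from all of them. No measured evidence is available to explain this step.

The compounds shown leave open whether the step goes with the six-membered ring or with its second nitrogen, as compound 4 brings in both at once, and a piperidin-1-yl or a morpholin-4-yl group on the same carbonyl carbon would separate the two. Also open, on these data alone, is whether the step survives a methyl or an acetyl group on the free ring nitrogen, and, with only one oral dose to read, how the compounds would compare as a matter of potency.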